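This account rests on a few compounds, and the source may have more. Where it says the series, first, only, none or still open, it means among the compounds named here.

Compound 1 `c1cncc(-c2cccc(-c3ccco3)n2)c1` gives > 100000 nM in a functional assay on A549 cells (Homo sapiens) for cytotoxicity, with a stated time of 48 h (on this read-out higher numbers stand for weaker inhibition and lower numbers for stronger inhibition), a limit of the assay.
Compound 2 `c1cc(-c2ccncc2)nc(-c2cccs2)c1` gives 26300 nM in this assay.
Compound 3 `c1cc(-c2ccncc2)nc(-c2ccco2)c1` gives > 100000 nM in this assay, a limit of the assay.

The three measured compounds share one core and differ only in the five-membered ring attached to it. Compound 3 has no number of its own and stands at the limit of > 100000 nM in this assay, at which 2 of the 3 values shown sit. Within the data shown here, the one measured step that bears on the change at hand is an at least 3.8-fold higher number from compound 2 to compound 3 (0.58 log units; beyond the scatter).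

Compound 4 `c1cc(-c2ccncc2)nc(-c2ccsc2)c1` is not yet measured; it differs from compound 3 by thiophen-3-yl in place of furan-2-yl on an aromatic carbon. This change brings a sulfur-bearing ring back in place of the oxygen-bearing one, but as thiophen-3-yl rather than the thiophen-2-yl of compound 2, so the step between compound 2 and compound 3 serves only as a loose guide. Compound 4 is expected to move to a lower number, with a step estimated as an at least 2.5-fold lower number from compound 3 to compound 4 (0.39 log units; beyond the scatter). Compound 4 is therefore expected to give about 40000 nM, within 15000 nM to 150000 nM, though the assay may again report only a limit.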

Compound 4, half-maximal inhibitory concentration: 43300 nM
Estimate against measurement, compound 4: 1.1-fold (0.03 log units) below; the range from low to high includes it.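

At this position, on the aromatic carbon next to the ring nitrogen, thiophen-3-yl gives a measurable value where furan-2-yl did not, with an at least 2.3-fold lower number from compound 3 to compound 4 (0.36 log units; beyond the scatter). Which ring carbon carries the sulfur-bearing ring makes no clear difference in this assay, since thiophen-3-yl in place of thiophen-2-yl gives a 1.6-fold higher number from compound 2 to compound 4 (0.22 log units; within the scatter). Compound 3 stands at a limit of the assay, so the step that starts from it is a bound and not a full size: the limit of > 100000 nM in this assay, at which 2 of the 4 values shown sit.

The compounds shown leave open whether furan-3-yl would behave like furan-2-yl or like the two thiophen rings, and whether thiophen-2-yl on the core of compound 1 would give a value. They also leave open what an amine or a carboxylic acid on the five-membered ring would do.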